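Swapping pyrrolidin-1-yl for a propoxyethyl chain on compound 3

The compounds below may be only part of what the source reports. "The series", "measured", "known", "first", "only" and "open" are said of these compounds alone.

In an ADME assay on Huh-7 cells (Homo sapiens) for cytotoxicity, read by MTT assay, with a stated time of 4 h, at 37 degrees C (a lower number here means that less compound is tolerated, a higher number that more compound is tolerated), compound 3 `Cn1c(=O)c(-c2ccc(F)cc2)cc2c(N3CCCC3)nc(N)nc21` gives 111000 nM. Compound 1 `CCCCCNc1nc(N)nc2c1cc(-c1ccc(F)cc1)c(=O)n2C` gives 79800 nM and compound 2 `O=C1Nc2nc(NCc3ccccc3)[nH]c(=O)c2CC1c1c(Cl)cccc1Cl` gives 69000 nM, so all three values lie within the scatter of one another, and compound 3 stands apart from neither.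

The next structure is compound 4 `CCCOCCNc1nc(N)nc2c1cc(-c1ccc(F)cc1)c(=O)n2C`, with (2-propoxyethyl)amino in place of pyrrolidin-1-yl on an aromatic carbon, next to the ring nitrogen: (2-propoxyethyl)amino in place of pyrrolidin-1-yl on an aromatic carbon.

For the measured compounds named here, one measured step bears on this change, at the same place on the shared core: a 1.4-fold higher number from compound 1 to compound 3 (0.14 log units; within the scatter). That step exchanged pentylamino for pyrrolidin-1-yl and stayed within the scatter. Going by the values given here, no measured compound carries (2-propoxyethyl)amino, so the expectation rests on this single step and is correspondingly loose.

No change beyond the scatter is expected in this assay, and the estimated step is a 1.2-fold lower number from compound 3 to compound 4 (0.09 log units; within the scatter). Compound 4 is estimated at 90000 nM, with an expected range of 45000 nM to 180000 nM.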

Compound 4, half-maximal cytotoxic concentration: 54300 nM
Beside the measured number, compound 4's estimate is 1.7-fold (0.22 log units) above it; the measured number falls inside the stated range.
By their numbers in this assay, from the lowest: compounds 4, 2, 1 and 3 (each within the scatter of the next, the first and the last beyond it).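

In (this assay) this position now shows a step beyond the scatter (a 2.0-fold lower number from compound 3 to compound 4 (0.31 log units; beyond the scatter)), whereas the earlier step at the same place stayed within it (a 1.4-fold higher number from compound 1 to compound 3 (0.14 log units; within the scatter)). Propoxy in place of propyl on the open chain stays within the scatter (a 1.5-fold lower number from compound 1 to compound 4 (0.17 log units; within the scatter)), so that exchange alone does not account for a step of the larger size. Among the three steps, only the one joining the highest and lowest numbers, with pyrrolidin-1-yl leaving and (2-propoxyethyl)amino entering, lies beyond the scatter, and no evidence at hand gives a cause for it.

The compounds shown do not separate the loss of the ring from the gain of the chain at this position. As far as these compounds go, how a piperidine ring, a morpholine ring or a chain ending in a carboxylic acid would read here also remains open.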